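The source may hold more compounds than are shown below. What is called first, only, known or untested is meant among the compounds shown, and "the series" means these compounds.

Working notes on the series. Compounds 1, 2 and 3 share one core and differ only in the amine carried on the saturated chain. Compound 1 `COc1cc2c(Oc3ccc(NC(=O)c4nn(-c5ccccc5OC(F)(F)F)c(=O)cc4C)cc3F)ccnc2cc1OCCCN1CCCC1` gives 60 nM in a functional assay on MKN-45 cells (Homo sapiens) for inhibition, read by MTT assay, with a stated time of 72 h; a higher number here means a weaker inhibitor, a lower number a stronger inhibitor. Compound 2 `COc1cc2c(Oc3ccc(NC(=O)c4nn(-c5ccccc5OC(F)(F)F)c(=O)cc4C)cc3F)ccnc2cc1OCCCN1CCC(C)CC1` gives 70 nM in this assay, and compound 3 `COc1cc2c(Oc3ccc(NC(=O)c4nn(-c5ccccc5OC(F)(F)F)c(=O)cc4C)cc3F)ccnc2cc1OCCCN1CCN(C)CC1` gives 100 nM. The steps among them are a 1.2-fold higher number from compound 1 to compound 2 (0.07 log units; within the scatter), a 1.7-fold higher number from compound 1 to compound 3 (0.22 log units; within the scatter) and a 1.4-fold higher number from compound 2 to compound 3 (0.15 log units; within the scatter); each lies within the scatter, so these amine exchanges produce nothing that can be read as a change. On the numbers, compound 2 is the second highest of the three, though its gaps to compound 1 and to compound 3 are both within the scatter.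

Compound 4 `COc1ccc(-n2nc(C(=O)Nc3ccc(Oc4ccnc5cc(OCCCN6CCC(C)CC6)c(OC)cc45)c(F)c3)c(C)cc2=O)cc1` is not yet measured. It departs from compound 2 at a different place: 4-methoxyphenyl in place of 2-(trifluoromethoxy)phenyl on an aromatic nitrogen. Within the data shown here, none of the measured steps touches the aryl group on the ring nitrogen; all three concern the amine at the chain end, so no measured step bears directly on this exchange, and nothing tells how the aryl end responds. The step expected from the exchange is a 1.4-fold higher number from compound 2 to compound 4 (0.15 log units; within the scatter), a placeholder for the absence of precedent rather than a read direction. The estimate for compound 4 in this assay is 100 nM, with a wide range from 30 nM to 350 nM.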

Compound 4, half-maximal inhibitory concentration: 400 nM
Compound 4: middle estimate off by 4.0-fold (0.60 log units), on the low side; measured number outside the range, above it.
By their numbers in this assay, from the lowest: compounds 1, 2 and 3 (each within the scatter of the next); then compound 4.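

In this assay, among these compounds, placing 4-methoxyphenyl in place of 2-(trifluoromethoxy)phenyl on the aromatic nitrogen gives a 5.7-fold higher number from compound 2 to compound 4 (0.76 log units; beyond the scatter) and is the first step to lie beyond the scatter. The aryl group on the ring nitrogen is therefore a place where the number responds, whereas the three amine exchanges at the chain end among compounds 1, 2 and 3 all stayed within the scatter, although this reading rests on a single step. No measurement at hand bears on the origin of this step, so no cause can be assigned to it.

The compounds shown do not separate the exchange of trifluoromethoxy for methoxy from the shift in substituent position, a question that 2-methoxyphenyl and 4-(trifluoromethoxy)phenyl on the same nitrogen would address, with unsubstituted phenyl as a further reference point. As far as these compounds go, it also remains open whether the amine at the chain end stays as inconsequential with 4-methoxyphenyl on the ring nitrogen, as a pyrrolidin-1-yl or 4-methylpiperazin-1-yl partner to compound 4 would show.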